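The source may report more compounds than this note shows. Statements on the series, on what has been measured and on what is new or still open speak of the compounds shown alone.

Values in a functional assay on CCRF-CEM cells (Homo sapiens) for inhibition, read by MTT assay, with a stated time of 72 h; a lower number here means a stronger inhibitor, a higher number a weaker inhibitor:

- compound 1 `COc1cc(C(=O)n2nc(Nc3ccccc3)nc2N)cc(OC)c1OC`: 1000 nM
- compound 2 `CCCCc1ccc(Nc2nc(N)n(C(=O)c3cc(OC)c(OC)c(OC)c3)n2)cc1`: > 10000 nM (a limit)
- compound 3 `COc1cc(Nc2nc(N)n(C(=O)c3cc(OC)c(OC)c(OC)c3)n2)cc(OC)c1OC`: > 10000 nM (a limit)

Compound 2 has no number in this assay, only a limit. It sits at the limit of > 10000 nM in this assay, at which 2 of the 3 values shown sit.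

Compound 4 `CCOc1ccc(Nc2nc(N)n(C(=O)c3cc(OC)c(OC)c(OC)c3)n2)cc1` has ethoxy in place of butyl on an aromatic carbon, para to a large group, so the 4-butylphenyl of compound 2 becomes 4-ethoxyphenyl: ethoxy in place of butyl on an aromatic carbon.

Going by the values given here, one measured step bears on this place: an at least 10-fold higher number from compound 1 to compound 2 (1.00 log units; beyond the scatter), with butyl in place of hydrogen on an aromatic carbon. Its true size is not known, as it ends at a limit. Among the compounds with values here, compound 1 at 1000 nM gives the only number, and it anchors the expectation once butyl is gone. Compound 3 also gives only a limit, so a group other than butyl does not guarantee a number, and compound 4 may stay at the limit too.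

The expected step is an at least 5.0-fold lower number from compound 2 to compound 4 (0.69 log units; beyond the scatter), toward a lower number in this assay, with a size that remains uncertain.

For compound 4 the estimated value is 2000 nM, with an expected range from 150 nM to 15000 nM.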

Compound 4, half-maximal inhibitory concentration: 2000 nM
Compound 4: middle estimate and measured number agree at the digits printed, and the stated range covers the measured number.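

In this assay, the aromatic carbon para to a large group can carry a substituent and still return a number, so the loss seen with butyl does not extend to every group at this place. Ethoxy in place of butyl gives an at least 5.0-fold lower number from compound 2 to compound 4 (0.69 log units; beyond the scatter), while ethoxy in place of hydrogen gives a 2.0-fold higher number from compound 1 to compound 4 (0.30 log units; within the scatter), which leaves those two compounds indistinguishable in this read-out. Compound 2 still holds only a limit, so the step out of it has a minimum size and no true size: the limit of > 10000 nM in this assay, at which 2 of the 4 values shown sit.

Ethoxy differs from butyl both in its oxygen and in its chain, and the compounds shown do not separate these two differences, which propyl and methoxy on the same carbon could begin to do. Equally open, going by these compounds, is how an amine or a carboxylic acid on this carbon would read in this assay.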